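This account rests on a few compounds, and the source may have more. Where it says the series, first, only, none or still open, it means among the compounds named here.

Two compounds share one core, and a third is built from it. Compound 1, `O=C(Nc1ccc(Oc2ccnc3[nH]ccc23)cc1)c1cc2cccnc2n(-c2ccc(F)c(Cl)c2)c1=O`, carries a 3-chloro-4-fluorophenyl group on the aromatic nitrogen of the core; in a functional assay on NCI-H460 cells (Homo sapiens) for antiproliferative activity, read by MTT assay, with a stated time of 72 h (on this read-out lower numbers stand for stronger inhibition and higher numbers for weaker inhibition), the entry for compound 1 reads "not determined" (no result reported), so no result was reported for it. Compound 2, `O=C(Nc1ccc(Oc2ccnc3[nH]ccc23)c(F)c1)c1cc2cccnc2n(-c2ccc(Br)cc2)c1=O`, carries a 4-bromophenyl group at that place and a fluorine on the aniline ring; in this assay compound 2 gives 260 nM. Within the data shown here, that is the only number available, so compound 2 cannot be ranked against anything else.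

Compound 3, `O=C(Nc1ccc(Oc2ccnc3[nH]ccc23)c(F)c1)c1cc2cccnc2n(-c2ccc(F)c(Cl)c2)c1=O`, is compound 2 with a single change: 3-chloro-4-fluorophenyl in place of 4-bromophenyl on an aromatic nitrogen. Nothing measured shows what this exchange does on this core, since compound 1 has no result. Among the measured compounds shown here, with only one halogenated phenyl ring exchanged for another at the same place, no step beyond the usual scatter of this assay is expected in either direction. The step from compound 2 to compound 3 is thus expected to be a 1.0-fold lower number from compound 2 to compound 3 (0.02 log units; within the scatter). Compound 3 is therefore estimated at 250 nM, with a likely range from 100 nM to 700 nM.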

Compound 3, half-maximal inhibitory concentration: 1050 nM
The estimate for compound 3 lay 4.2-fold (0.62 log units) below the measured number; measured number outside the range, above it.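

In this assay, replacing 4-bromophenyl with 3-chloro-4-fluorophenyl on the aromatic nitrogen gives a 4.0-fold higher number from compound 2 to compound 3 (0.61 log units; beyond the scatter). This shows that the position is not indifferent to the choice between these two halogenated phenyl rings: although both are single six-membered aromatic rings of carbon with no hydrogen-bond donors or acceptors, the higher number means weaker inhibition with the 3-chloro-4-fluorophenyl group on this core. The change removes a bromine and adds both a chlorine and a fluorine, so this single step cannot be divided among those atoms, and nothing available explains why the number rises.

From the compounds shown here alone, compound 1 offers no number for comparison, so it remains unknown whether the same exchange would have a similar effect on the shared core without the fluorine on the aniline ring. The compounds shown also leave open how an unsubstituted phenyl, 4-chlorophenyl or 4-fluorophenyl group would behave at this position, and whether a phenyl ring carrying an amine or a carboxylic acid would be tolerated there.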